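A trimethoxyphenyl swap on compound 3

The compounds below may be only part of what the source reports. "The series", "measured", "known", "first", "only" and "open" are said of these compounds alone.

Compound 1 `O=C(N/N=C/c1cccc(Br)c1)Nc1cc2c(Nc3ccc(F)c(Cl)c3)ncnc2cc1O[C@H]1CCOC1`: 10700 nM
Compound 2 `N#Cc1ccc(/C=N/NC(=O)Nc2cc3c(Nc4ccc(F)c(Cl)c4)ncnc3cc2O[C@H]2CCOC2)cc1`: 29100 nM
Compound 3 `COc1ccc(/C=N/NC(=O)Nc2cc3c(Nc4ccc(F)c(Cl)c4)ncnc3cc2O[C@H]2CCOC2)cc1`: 33100 nM

These values come from a functional assay on A549 cells (Homo sapiens) for cytotoxicity, read by MTT assay, with a stated time of 72 h; on this read-out higher numbers stand for weaker inhibition and lower numbers for stronger inhibition. Compound 3 stands level with compound 2 at the high end of the three numbers, with a 1.1-fold higher number from compound 2 to compound 3 (0.06 log units; within the scatter). Compound 1 gives the lowest number. Compound 4 `COc1cc(/C=N/NC(=O)Nc2cc3c(Nc4ccc(F)c(Cl)c4)ncnc3cc2O[C@H]2CCOC2)cc(OC)c1OC` differs from compound 3 in one place: 3,4,5-trimethoxyphenyl in place of 4-methoxyphenyl on a carbon with a double bond to nitrogen. Three measured steps change the group at this place. They are modest or smaller: a 2.7-fold higher number from compound 1 to compound 2 (0.43 log units; beyond the scatter), a 3.1-fold higher number from compound 1 to compound 3 (0.49 log units; beyond the scatter), and the step between compound 2 and compound 3 already given. No step beyond the scatter is therefore expected in this assay. The expected change is a 1.3-fold lower number from compound 3 to compound 4 (0.10 log units; within the scatter). For compound 4 the estimated value is 26000 nM, with an expected range of 11000 nM to 60000 nM.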

Compound 4, half-maximal inhibitory concentration: 26400 nM
For compound 4 the middle estimate is 1.0-fold (0.01 log units) below the measured one, and the stated range covers the measured number.
By their numbers in this assay, from the lowest: compound 1; then compounds 4, 2 and 3 (each within the scatter of the next).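

In this assay, the 3,4,5-trimethoxyphenyl group sits level with the two para-free comparison groups at this place: a 1.3-fold lower number from compound 3 to compound 4 (0.10 log units; within the scatter) and a 1.1-fold lower number from compound 2 to compound 4 (0.04 log units; within the scatter) both stay within the scatter. Only the 3-bromophenyl group stands apart, with a 2.5-fold higher number from compound 1 to compound 4 (0.39 log units; beyond the scatter), so compounds 2, 3 and 4 now form one group despite their different aryl substituents. No measurement at hand explains these numbers. As far as these compounds go, whether the lower number of compound 1 belongs to bromine itself stays open, as does the effect of a morpholine or a carboxylic acid on this phenyl ring.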